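Heteroaryl exchange on the shared core: toward compound 4

The source may report more compounds than this note shows. Statements on the series, on what has been measured and on what is new or still open speak of the compounds shown alone.

In an ADME assay on MT4 cells (Homo sapiens) for cytotoxicity, read by MTT assay, with a stated time of 5 days (a lower number here means that less compound is tolerated, a higher number that more compound is tolerated), compound 1 `Cc1cc(C)cc(-c2cnc(Nc3ccc(C#N)cc3)nc2Oc2c(C)cc(C#N)cc2C)c1` gives 39000 nM, compound 2 `Cc1cc(C#N)cc(C)c1Oc1nc(Nc2ccc(C#N)cc2)ncc1-c1ccoc1` gives 4980 nM and compound 3 `Cc1cc(C#N)cc(C)c1Oc1nc(Nc2ccc(C#N)cc2)ncc1-c1ccsc1` gives 3920 nM. Compound 3 and compound 2 sit within the scatter of each other, while compound 1 lies clearly higher than both. Compound 4 `Cc1cc(C#N)cc(C)c1Oc1nc(Nc2ccc(C#N)cc2)ncc1-c1cncnc1` carries pyrimidin-5-yl in place of thiophen-3-yl on an aromatic carbon. Among the compounds with values here, the steps that bear on this are a 9.9-fold lower number from compound 1 to compound 3 (1.00 log units; beyond the scatter) and a 7.8-fold lower number from compound 1 to compound 2 (0.89 log units; beyond the scatter), both modest, and most directly a 1.3-fold lower number from compound 2 to compound 3 (0.10 log units; within the scatter), where one small heteroaryl replaced another without moving the number beyond the scatter. A further heteroaryl exchange of the same kind is therefore expected to stay within the scatter in this assay, and the expected step is a 1.3-fold higher number from compound 3 to compound 4 (0.11 log units; within the scatter). The estimate for compound 4 is 5000 nM, with a range from 2000 nM to 15000 nM.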

Compound 4, half-maximal cytotoxic concentration: > 298000 nM
Compound 4: a limit, no number (the forecaster's own chance of this, stated with the estimate: 10%); at least 59-fold (1.77 log units) between middle value and limit.
By their numbers in this assay, from the lowest: compounds 3 and 2 (each within the scatter of the next); then compound 1. At a limit, above all of these: compound 4.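

In this assay, pyrimidin-5-yl gives an at least 76-fold higher number from compound 3 to compound 4 (1.88 log units; beyond the scatter) and an at least 59-fold higher number from compound 2 to compound 4 (1.77 log units; beyond the scatter), so heteroaryl exchange at this position is not always as quiet as a 1.3-fold lower number from compound 2 to compound 3 (0.10 log units; within the scatter) suggested. The same group also gives an at least 7.6-fold higher number from compound 1 to compound 4 (0.88 log units; beyond the scatter), which puts the six-membered pyrimidin-5-yl ring on the opposite side of 3,5-dimethylphenyl from the two five-membered rings. Compound 4 gives a limit of the assay, not a number: the limit of > 298000 nM in this assay, at which 1 of the 4 values shown sits.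

On these data alone, how far compound 4 lies past that limit remains open. With only these compounds, ring size and ring nitrogen count cannot be separated, and a pyridin-3-yl group at this position would be needed to tell them apart.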